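A few compounds are considered here, and "the series" means these few. Any claim that something is new, unique, unknown or untested is made for them only; others in the source may bear on it.

Measured compounds:
compound 1 `Cc1nc(-c2cc(C(F)(F)F)ccc2[C@@H]2CCOc3cc(S(=O)(=O)Nc4nccs4)ccc32)co1` with 130000 nM
compound 2 `O=S(=O)(Nc1nccs1)c1ccc2c(c1)OCC[C@@H]2c1ccc(C(F)(F)F)cc1-c1nccs1` with 15000 nM
compound 3 `O=S(=O)(Nc1nccs1)c1ccc2c(c1)OCC[C@H]2c1ccc(C(F)(F)F)cc1-c1ccc(F)cc1` with 147000 nM

In a physicochemical assay for solubility (on this read-out higher numbers stand for higher solubility and lower numbers for lower solubility), compound 3 holds the highest number of the three. Compound 1 sits within the scatter of it, while compound 2 lies well below it, beyond the scatter. Compound 4 `O=S(=O)(Nc1nccs1)c1ccc2c(c1)OCC[C@H]2c1ccc(C(F)(F)F)cc1-c1nccs1` has not yet been measured. It differs from compound 3 in one place: 1,3-thiazol-2-yl in place of 4-fluorophenyl on an aromatic carbon. Within the data shown here, the one measured step of the same kind, a 1.1-fold higher number from compound 1 to compound 3 (0.05 log units; within the scatter), shows that exchanging one ring group for another on this aromatic carbon left the number unchanged within the scatter. A different pointer comes from compound 2, which also carries a 1,3-thiazol-2-yl group and gives 15000 nM, a number clearly below that of compound 3. Weighing both, a drop beyond the scatter is expected for compound 4, of about an 8.2-fold lower number from compound 3 to compound 4 (0.91 log units; beyond the scatter). Compound 4 is therefore estimated at 18000 nM, with a likely range from 7000 nM to 50000 nM.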

Compound 4, solubility: 7000 nM
Compound 4: middle estimate off by 2.6-fold (0.41 log units), on the high side; low and high end bracket the measured number.
By their numbers in this assay, from the lowest: compound 4; then compound 2; then compounds 1 and 3 (each within the scatter of the next).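

Within this assay, the ring group on this aromatic carbon now clearly matters. The earlier step, a 1.1-fold higher number from compound 1 to compound 3 (0.05 log units; within the scatter), could not separate 4-fluorophenyl from 2-methyl-1,3-oxazol-4-yl, but 1,3-thiazol-2-yl stands apart from both, with a 21-fold lower number from compound 3 to compound 4 (1.32 log units; beyond the scatter) and a 19-fold lower number from compound 1 to compound 4 (1.27 log units; beyond the scatter). The configuration at the saturated ring carbon also counts, though the change is much smaller, a 2.1-fold lower number from compound 2 to compound 4 (0.33 log units; beyond the scatter), and it can be tied to that stereocentre alone: the fact that compounds 2 and 4 differ only in the configuration as drawn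

The compounds shown leave open whether a configuration step of this kind would also appear with 4-fluorophenyl or 2-methyl-1,3-oxazol-4-yl in place of 1,3-thiazol-2-yl. They also leave open what an unsubstituted phenyl ring, an amine or a carboxylic acid on this aromatic carbon would give.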